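Methoxy addition on the cinnamoyl ring: unmeasured ortho case

The source may report more compounds than this note shows. Statements on the series, on what has been measured and on what is new or still open speak of the compounds shown alone.

Compound 1 `C=C(Br)C(=O)Nc1ccc(C(=O)/C=C/c2cccc(OC)c2)cc1` and compound 2 `C=C(Br)C(=O)Nc1ccc(C(=O)/C=C/c2cc(OC)cc(OC)c2)cc1` share a core; compound 2 differs by methoxy in place of hydrogen on an aromatic carbon. In a functional assay on FM3A cells (Mus musculus) for antiproliferative activity, with a stated time of 48 h (a higher number here means a weaker inhibitor, a lower number a stronger inhibitor), compound 1 gives 1800 nM and compound 2 gives 2000 nM, a step of a 1.1-fold higher number from compound 1 to compound 2 (0.05 log units; within the scatter). Compound 3 `Nc1ccc(C(=O)/C=C/c2ccccc2)cc1` has a different core, and the difference between the two cores is not broken down here; in this assay compound 3 gives 34000 nM, well apart from compound 1 and compound 2. Compound 4 `COc1ccccc1/C=C/C(=O)c1ccc(N)cc1` differs from compound 3 by methoxy in place of hydrogen on an aromatic carbon. The change is the same kind as that from compound 1 to compound 2, but the place differs: ortho to a large group rather than meta to a large group and meta to a methoxy group. Since the measured step of this kind was within the scatter, the step from compound 3 to compound 4 is expected to be small, a 1.1-fold lower number from compound 3 to compound 4 (0.05 log units; within the scatter). Compound 4 is estimated at 30000 nM, between 12000 nM and 80000 nM.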

Compound 4, half-maximal inhibitory concentration: 25000 nM
Estimate against measurement, compound 4: 1.2-fold (0.08 log units) above, and the stated range covers the measured number.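

In this assay, methoxy in place of hydrogen on an aromatic carbon gives a 1.4-fold lower number from compound 3 to compound 4 (0.13 log units; within the scatter). Set beside the earlier step on the other core, this step does not differ from it: the same change on two cores in this assay, a 1.1-fold higher number (0.05 log units; within the scatter) from compound 1 to compound 2 and a 1.4-fold lower number (0.13 log units; within the scatter) from compound 3 to compound 4, 1.5-fold (0.18 log units) apart, within the scatter of two such steps. For the compounds shown here, the change therefore stays within the scatter on both cores, but this rests on only two pairs with the methoxy at different places, and it does not show that the step stays this small at other places or on further cores.

Open, going by these compounds, is whether an amine, a carboxylic acid or a longer alkoxy chain in place of that hydrogen would give a step beyond the scatter. Also open is what the difference between the two cores contributes, as no pair shown isolates it.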